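Methoxy removal from compound 1: estimate for compound 4

A few compounds are considered here, and "the series" means these few. Any claim that something is new, unique, unknown or untested is made for them only; others in the source may bear on it.

Measured compounds in a functional assay on HEK293 cells for agonist activity at D(4) dopamine receptor (Homo sapiens), read by FLIPR; on this read-out higher numbers stand for larger maximal responses and lower numbers for smaller maximal responses:
- compound 1 `COc1ccccc1C1CCN(CC(=O)Nc2cccc(C)c2)CC1`: 43%
- compound 2 `COc1cccc(C)c1NC(=O)CN1CCC(c2cccc[n+]2[O-])CC1`: 56%
- compound 3 `Cc1cccc(Cl)c1NC(=O)CN1CCC(c2ccccn2)CC1`: 70%

Compound 1 stands lowest of the three numbers in this assay. Nearest to it is compound 2, whose value lies higher by a margin beyond the scatter; compound 3 lies furthest, higher by a larger margin, also beyond the scatter. Both of these compounds differ from compound 1 in more than one place, so no step covering a single change is available, and what the two higher values show cannot be tied to any one part of the structure.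

Compound 4 `Cc1cccc(NC(=O)CN2CCC(c3ccccc3)CC2)c1` has not yet been measured in this assay. It differs from compound 1 in one place: hydrogen in place of methoxy on an aromatic carbon. Among the compounds with values here, the measured set holds no pair that isolates this change, so the direction of the step is open. With nothing to argue for a large shift, the step of a number 7 percentage points higher from compound 1 to compound 4 (within the scatter) is expected to stay within the usual scatter, with a wide band of uncertainty. Compound 4 is therefore expected to give about 50%, with a range from 30% to 70%.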

Compound 4, largest response reached (reported as efficacy), in percent of the reference or control that the assay uses: 37%
Beside the measured number, compound 4's estimate is 13 percentage points above it; low and high end bracket the measured number.
By their numbers in this assay, from the lowest: compounds 4 and 1 (each within the scatter of the next); then compound 2; then compound 3.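

In this assay, within the data shown here, hydrogen in place of methoxy on an aromatic carbon, ortho to a large group, gives a number 6 percentage points lower from compound 1 to compound 4 (within the scatter), the first single-change comparison. At this position the methoxy is therefore not required for the maximal response to stay at the level seen for compound 1, and the 2-methoxyphenyl to phenyl change leaves the read-out without a distinguishable shift. No measured evidence on the series bears on the reason for this result.

Still open, going by these compounds, is whether other groups at this position, such as a hydroxyl, a fluorine or an ethoxy, would also leave the maximal response unchanged on the core of compound 1. Also open, on these data alone, is whether a methoxy placed elsewhere on the same ring would read the same way.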